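Moving a Hydroxy Group and Cytotoxicity on Vero Cells

The source may hold more compounds than are shown below. What is called first, only, known or untested is meant among the compounds shown, and "the series" means these compounds.

Compound 1 `O=C1CSC(c2cccc(Cl)c2)N1CCN1CCCCC1` carries a chloro group on its aromatic ring. In an ADME assay on Vero cells (Chlorocebus sabaeus) for cytotoxicity, read by neutral red uptake, tested at 12.3 ug/mL (on this read-out lower numbers stand for a stronger effect and higher numbers for a weaker effect at the one concentration tested), compound 1 gives 100%, which means no loss of cell viability at the single concentration tested. Compound 2 `O=C1CSC(c2cccc(O)c2)N1CCN1CCCCC1` has a hydroxy group in place of that chloro; in this assay compound 2 gives 100%. The step of no change at the digits printed from compound 1 to compound 2 (within the scatter) shows that this exchange left the read-out where it was, so compound 2 stands level with compound 1 on this measure.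

Compound 3 `O=C1CSC(c2ccc(O)cc2)N1CCN1CCCCC1` has not been measured. It differs from compound 2 only in where the hydroxy group sits on the same aromatic ring: 4-hydroxyphenyl in place of 3-hydroxyphenyl on a saturated ring carbon. Among the measured compounds shown here, the one measured step, which also altered that ring, produced no movement, and nothing in these two values points to a different outcome for a change of the same ring. The expected step is therefore no change at the digits printed from compound 2 to compound 3 (within the scatter), nothing beyond the scatter. Compound 3 is estimated to give 100% in this assay, with a range from 88% to 105%.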

Compound 3, a percentage reported as activity, at one concentration (the size of the read-out at that concentration, not a potency): 100%
Beside the measured number, compound 3's estimate shows no gap at the digits printed, within the range that was stated.
By their numbers in this assay, from the lowest: compounds 1, 2 and 3 (each within the scatter of the next).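

Moving the hydroxy group, with 4-hydroxyphenyl in place of 3-hydroxyphenyl on a saturated ring carbon, gives no change at the digits printed from compound 2 to compound 3 (within the scatter) in this assay. On this read-out, then, these two compounds, which have the same atoms joined differently, cannot be told apart by where the hydroxy group sits on the aromatic ring. The wider exchange of 3-chlorophenyl for 4-hydroxyphenyl gives no change at the digits printed from compound 1 to compound 3 (within the scatter), so the three aromatic groups shown so far also cannot be told apart at the one concentration tested, and no supporting data are available to explain this flat result.

From the compounds shown here alone, whether a different kind of group on that aromatic ring, such as an amine, a carboxylic acid or a methoxy group, would shift the read-out remains open. A single concentration also leaves open whether these three compounds would still look alike at a higher concentration, where any loss of cell viability might begin to separate them.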